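Methylsulfanyl for Methylamino at the Aromatic Carbon

The compounds below may be only part of what the source reports. "The series", "measured", "known", "first", "only" and "open" are said of these compounds alone.

Among the measured compounds shown here, compound 2 `CNc1ccccc1N1CCN(CCCCn2ncc(=O)n(C)c2=O)CC1` gives 450 nM in an assay for displacement of a labelled ligand from Adrenergic receptor alpha-1 (Homo sapiens) (on this read-out higher numbers stand for weaker inhibition and lower numbers for stronger inhibition), one of two values so far; compound 1 `CN(C)c1ccccc1N1CCN(CCCCn2ncc(=O)n(C)c2=O)CC1` gives 350 nM, and the step of a 1.3-fold higher number from compound 1 to compound 2 (0.11 log units; within the scatter) lies within the scatter. Compound 3 `CSc1ccccc1N1CCN(CCCCn2ncc(=O)n(C)c2=O)CC1` differs from compound 2 by methylsulfanyl in place of methylamino on an aromatic carbon. For the measured compounds named here, the only measured step, a 1.3-fold higher number from compound 1 to compound 2 (0.11 log units; within the scatter), alters the same group by a different exchange and stayed within the scatter, so nothing in the data points to a sizeable move. The expected change is then a 1.1-fold lower number from compound 2 to compound 3 (0.05 log units; within the scatter), nothing beyond the scatter. Compound 3 is estimated at 400 nM, within a range of 150 nM to 1100 nM.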

Compound 3, inhibition constant: 1.8 nM
Estimate against measurement, compound 3: 220-fold (2.35 log units) above; the whole stated range lies above it.
By their numbers in this assay, from the lowest: compound 3; then compounds 1 and 2 (each within the scatter of the next).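

In this assay this aromatic carbon proves far more sensitive than the earlier pair suggested: methylsulfanyl in place of methylamino gives a 250-fold lower number from compound 2 to compound 3 (2.40 log units; beyond the scatter) and methylsulfanyl in place of dimethylamino gives a 190-fold lower number from compound 1 to compound 3 (2.29 log units; beyond the scatter) as the same large move. Exchanging one amino group for the other stayed within the scatter, so the large step appears only when methylsulfanyl enters. Nothing available accounts for this step. From the compounds shown here alone, whether methoxy or ethylsulfanyl on this carbon would give a similarly low number stays open.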